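From 2,3-difluorophenyl to 2,3-dichlorophenyl on the carbonyl

The source may hold more compounds than are shown below. What is called first, only, known or untested is meant among the compounds shown, and "the series" means these compounds.

Two compounds of the series have readings so far in an ADME assay on MT4 cells (Homo sapiens) for cytotoxicity, read by MTT assay; on this read-out higher numbers stand for lower toxicity in this test and lower numbers for higher toxicity in this test. Compound 1 (`Cc1ccc(N(C(=O)c2ccc([N+](=O)[O-])cc2)C(=S)OCCN2C(=O)c3ccccc3C2=O)cc1`) gives 58000 nM, and compound 2 (`O=C1c2ccccc2C(=O)N1CCOC(=S)N(C(=O)c1cccc(F)c1F)c1ccc(Cl)cc1`) gives 58000 nM. Compound 2 therefore stands level with compound 1 at the digits shown, within the scatter.

Compound 3 (`O=C1c2ccccc2C(=O)N1CCOC(=S)N(C(=O)c1cccc(Cl)c1Cl)c1ccc(Cl)cc1`) has 2,3-dichlorophenyl in place of 2,3-difluorophenyl on a carbonyl carbon, and the rest of compound 2 is kept: 2,3-dichlorophenyl in place of 2,3-difluorophenyl on a carbonyl carbon. Going by the values given here, no pair of measured compounds differs in one place only, so the data hold no direct precedent for this exchange. Among the compounds with values here, the only guide is that compound 1 differs from compound 2 in more than one place, yet compound 1 reads 58000 nM and compound 2 reads 58000 nM.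

In this assay, no step beyond the scatter is therefore expected, and no direction is favoured with any confidence. The expected change is a 1.2-fold lower number from compound 2 to compound 3 (0.06 log units; within the scatter). For compound 3 the estimated value is 50000 nM, with an expected range of 22000 nM to 100000 nM.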

Compound 3, half-maximal cytotoxic concentration: 54000 nM
For compound 3 the middle estimate is 1.1-fold (0.03 log units) below the measured one; low and high end bracket the measured number.
By their numbers in this assay, from the lowest: compounds 3, 1 and 2 (each within the scatter of the next).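

In this assay the exchange of 2,3-difluorophenyl for 2,3-dichlorophenyl on a carbonyl carbon gives a 1.1-fold lower number from compound 2 to compound 3 (0.03 log units; within the scatter) and this step lies within the scatter. Going by these compounds alone, it is the only reading in which a single place changes while the rest of the molecule is held, something compound 1 could not offer, as it differs from compound 2 in more than one place. At this position, on a carbonyl carbon whose other neighbour is the amide-type nitrogen, this read-out does not separate the two halogenated phenyl groups, and nothing measured here bears on why the reading stays level.

On these data alone, whether a group of a different kind on this carbonyl, such as a pyridine ring, a carboxylic acid or an aliphatic amine, would move the number beyond the scatter remains open. Also open, as far as these compounds go, is whether a longer chain elsewhere in the shared core would leave the reading level, as this single exchange speaks for one place only.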